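Thiomorpholine for Morpholine: Expected Growth Inhibition of Compound 4

The compounds below may be only part of what the source reports. "The series", "measured", "known", "first", "only" and "open" are said of these compounds alone.

Three compounds have been measured in a functional assay on HeLa cells (Homo sapiens) for cytotoxicity, read by MTT assay, with a stated time of 72 h, tested at 100 uM; a lower number here means less inhibition of growth, a higher number more inhibition of growth at the concentration tested:

Compound 1 `Cc1cccc(/C(N)=N/NC(=S)N2CCCCC2)n1` gives 85.4%.
Compound 2 `N/C(=N\NC(=S)N1CCOCC1)c1ccc(F)cn1` gives 81.2%.
Compound 3 `N/C(=N\NC(=S)N1CCOCC1)c1ccccn1` gives 87.2%.

Compound 2 has the lowest of the three numbers, but all three lie close together: compound 1 and compound 3 sit within the scatter of compound 2, so none of them can be called more or less active than another on these data.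

Compound 4 `N/C(=N\NC(=S)N1CCSCC1)c1ccc(F)cn1` has not been measured. It differs from compound 2 in one place: thiomorpholin-4-yl in place of morpholin-4-yl on a thiocarbonyl carbon. Among the measured compounds shown here, the only step measured so far changes a different part of the molecule, a hydrogen in place of fluoro on an aromatic carbon, and it gave a number 6 percentage points higher from compound 2 to compound 3 (within the scatter). For the measured compounds named here, no measured step touches the group on the thiocarbonyl carbon, so nothing here shows how exchanging morpholin-4-yl for thiomorpholin-4-yl affects growth inhibition. With both groups the same size and the shared core unchanged, the expected step of a number 0.8 percentage points higher from compound 2 to compound 4 (within the scatter) is none beyond the scatter. Compound 4 is therefore estimated to give 82%, with a range from 70% to 92%.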

Compound 4, percent growth inhibition at one concentration: 88.1%
For compound 4 the middle estimate is 6.1 percentage points below the measured one; the measured number falls inside the stated range.
By their numbers in this assay, from the lowest: compounds 2, 1, 3 and 4 (each within the scatter of the next).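

Among the compounds shown here, this is the first step in the set that touches the group on the thiocarbonyl carbon. In this assay, thiomorpholin-4-yl in place of morpholin-4-yl, a swap of the ring oxygen for sulfur in a ring of the same size, gives (a number 6.9 percentage points higher from compound 2 to compound 4 (within the scatter)), so the two rings cannot be told apart at this position in this assay. Growth inhibition therefore stays in the same band as the other compounds after this exchange, although no reason for this can be given, as nothing at hand bears on how either ring acts in these cells.

On these data alone, whether this position accepts any ring or only these two stays open, since a piperazine ring carrying a second ring nitrogen, or an open-chain group such as diethylamino, would test it much harder than a single atom swap. Also open, as far as these compounds go, is whether the two rings would still match at lower concentrations, since a reading at one concentration, with all the numbers this close, cannot separate them.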